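Swapping the oxygen substituent on the shared core

The compounds below may be only part of what the source reports. "The series", "measured", "known", "first", "only" and "open" are said of these compounds alone.

Measured in a functional assay for inhibition; a lower number here means a stronger inhibitor, a higher number a weaker inhibitor:
- compound 1 `CC(C)(C)c1cc(-c2cc(=O)c3ccc(OCc4ccc(Cl)cc4)cc3o2)cc(C(C)(C)C)c1O`: 7000 nM
- compound 2 `CCOC(=O)C(C)(C)Oc1ccc2c(=O)cc(-c3cc(C(C)(C)C)c(O)c(C(C)(C)C)c3)oc2c1`: 3000 nM

Of these two, compound 2 has the lower number, at 3000 nM. The next compound is compound 3 `CCN(CC)C(=O)COc1ccc2c(=O)cc(-c3cc(C(C)(C)C)c(O)c(C(C)(C)C)c3)oc2c1`, which carries (diethylcarbamoyl)methyl in place of 1-(ethoxycarbonyl)-1-methylethyl on an oxygen on an aromatic ring.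

Going by the values given here, only one measured step bears on this place: a 2.3-fold lower number from compound 1 to compound 2 (0.37 log units; beyond the scatter). That modest step replaced 4-chlorobenzyl with the group now leaving. Among the compounds with values here, no measured compound carries (diethylcarbamoyl)methyl, so the data give no direction for the new change. A step of about that modest size or smaller is therefore expected in this assay, with either sign possible. The expected outcome is a 1.3-fold higher number from compound 2 to compound 3 (0.12 log units; within the scatter). Compound 3 is estimated at 4000 nM, with an expected range of 1300 nM to 12000 nM.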

Compound 3, half-maximal inhibitory concentration: 3000 nM
Beside the measured number, compound 3's estimate is 1.3-fold (0.12 log units) above it, within the range that was stated.
By their numbers in this assay, from the lowest: compounds 2 and 3 (each within the scatter of the next); then compound 1.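

In this assay, the change to (diethylcarbamoyl)methyl on the oxygen gives no change at the digits printed from compound 2 to compound 3 (within the scatter), so the number does not depend on keeping the 1-(ethoxycarbonyl)-1-methylethyl group. Against the 4-chlorobenzyl group, the new compound repeats the earlier gain, with a 2.3-fold lower number from compound 1 to compound 3 (0.37 log units; beyond the scatter); among these compounds, the two groups without a ring both sit beyond the scatter from compound 1, so that gain is not particular to the ester-bearing group. No supporting data are available to account for compound 2 and compound 3 reading alike.

On these data alone, it remains open whether a carboxylic acid, a basic amine or a longer chain on this oxygen would move the number further in either direction. As far as these compounds go, it is also open how much of the level of these numbers is set by the shared core rather than by this substituent.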